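From methoxy to butoxy: an estimate for compound 4

This account rests on a few compounds, and the source may have more. Where it says the series, first, only, none or still open, it means among the compounds named here.

Measured in a functional assay on HL-60 cells (Homo sapiens) for cytotoxicity, read by WST assay, with a stated time of 48 h; on this read-out higher numbers stand for an effect only at larger amounts of compound and lower numbers for an effect already at smaller amounts:
- Compound 1 `CCCCOc1cccc(C[C@H]2C(=O)OC[C@@H]2Cc2ccccc2)c1` gives 26000 nM
- Compound 2 `O=C1OC[C@H](Cc2ccccc2)[C@H]1Cc1ccc(O)cc1` gives 88000 nM
- Compound 3 `COc1cc(C[C@H]2C(=O)OC[C@@H]2Cc2ccccc2)ccc1O` gives 93000 nM

Compound 3 lies within the scatter of compound 2, while compound 1 shows a lower number, beyond the scatter. Compound 4 `CCCCOc1cc(C[C@H]2C(=O)OC[C@@H]2Cc2ccccc2)ccc1O` differs from compound 3 by propyl in place of hydrogen on a saturated chain carbon bound to an oxygen on an aromatic ring, so methoxy becomes butoxy.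

Going by the values given here, the one measured step, a 1.1-fold higher number from compound 2 to compound 3 (0.02 log units; within the scatter), introduced methoxy in place of hydrogen on an aromatic carbon and stayed within the scatter. It does not test chain length. The closest guide is compound 1 at 26000 nM, which also carries butoxy but has no hydroxy group. A modest move to a lower number is therefore expected, and the estimated step is a 2.3-fold lower number from compound 3 to compound 4 (0.37 log units; beyond the scatter) in this assay. The estimate for compound 4 is 40000 nM with an expected range from 15000 nM to 100000 nM.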

Compound 4, half-maximal effective concentration: 35000 nM
For compound 4 the middle estimate is 1.1-fold (0.06 log units) above the measured one; the range from low to high includes it.
By their numbers in this assay, from the lowest: compounds 1 and 4 (each within the scatter of the next); then compounds 2 and 3 (each within the scatter of the next).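

Extending methoxy to butoxy in this assay gives a change beyond the scatter (a 2.7-fold lower number from compound 3 to compound 4 (0.42 log units; beyond the scatter)), so chain length on this saturated chain carbon bound to an oxygen on an aromatic ring moves the number, which the methoxy step alone, lying within the scatter, did not show. Swapping an aromatic hydrogen for butoxy gives a step of similar size (a 2.5-fold lower number from compound 2 to compound 4 (0.40 log units; beyond the scatter)), whereas methoxy in that role did not. With butoxy present, swapping an aromatic hydrogen for hydroxy stays within the scatter (a 1.3-fold higher number from compound 1 to compound 4 (0.13 log units; within the scatter)), so this pair shows no effect of the hydroxy group on the number.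

No evidence at hand bears on this result. On these data alone, whether a longer chain than butoxy would lower the number further, or an amine in place of the hydroxy would change it, stays open.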